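The source may report more compounds than this note shows. Statements on the series, on what has been measured and on what is new or still open speak of the compounds shown alone.

Compound 1 `CCCSc1nc(N/N=C/c2ccc(C)cc2)c2nnn(Cc3ccccc3)c2n1` carries a 4-methylphenyl group on a carbon with a double bond to nitrogen. In a functional assay on MCF7 cells (Homo sapiens) for antiproliferative activity, read by MTT assay, with a stated time of 72 h (a higher number here means a weaker inhibitor, a lower number a stronger inhibitor), compound 1 gives > 64000 nM, which is a limit of the assay rather than a measured number. The related compound 2 `CCCSc1nc(N/N=C(\C)c2ccccc2O)c2nnn(Cc3ccc(F)cc3)c2n1` gives > 64000 nM in this assay, again a limit. Among the compounds with values here, the evidence at hand is therefore (the limit of > 64000 nM in this assay, at which 2 of the 2 values shown sit), and no step between two numbered values exists to lean on.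

Compound 3 `CCCSc1nc(N/N=C/c2c[nH]c3ccccc23)c2nnn(Cc3ccccc3)c2n1` has not yet been measured in this assay. It differs from compound 1 by 1H-indol-3-yl in place of 4-methylphenyl on a carbon with a double bond to nitrogen. With compound 1 standing only at a limit, the size of the step from compound 1 to compound 3 cannot be anchored, and the expected change is a step that the limit leaves unreadable from compound 1 to compound 3, which is no change beyond the scatter. Compound 3 is expected to give 80000 nM in this assay, with a likely range from 25000 nM to 250000 nM.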

Compound 3, half-maximal inhibitory concentration: 9010 nM
Estimate against measurement, compound 3: 8.9-fold (0.95 log units) above; the whole stated range lies above it.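

In this assay, compound 3 gives 9010 nM, a measured number. Within the data shown here, this is the first sign that the group on a carbon with a double bond to nitrogen can bring the series off the assay's limit. Putting 1H-indol-3-yl in place of 4-methylphenyl produces an at least 7.1-fold lower number from compound 1 to compound 3 (0.85 log units; beyond the scatter). That step is only a minimum, as its starting point is a limit rather than a number, and most of the series shown still sits at that limit: the limit of > 64000 nM in this assay, at which 2 of the 3 values shown sit.

The change brings in a hydrogen-bond donor and a second ring together, and the compounds shown do not separate the two. Also open, as far as these compounds go, is how a naphthyl group, which has two rings and no nitrogen, would behave in this place.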